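A Dichlorophenyl Thioether Analogue Awaiting Its Cell Test

A few compounds are considered here, and "the series" means these few. Any claim that something is new, unique, unknown or untested is made for them only; others in the source may bear on it.

Compound 3 `Nc1cc(N)c2nc(-c3ccccc3)c(Sc3ccc(F)cc3)nc2c1` was examined in a functional assay on KM12 cells (Homo sapiens) for inhibition, read by sulforhodamine B assay, with a stated time of 48 h; on this read-out higher numbers stand for lower toxicity in this test and lower numbers for higher toxicity in this test. In this assay compound 3 gives < 100000 nM, which is a limit of the assay rather than a number. Compound 1 `Nc1cc(N)c2nc(-c3ccccc3)c(NCc3ccc(Cl)c(Cl)c3)nc2c1` gives < 100000 nM in this assay, likewise only a limit. Compound 2 `CCOC(=O)[C@H](CCC(=O)O)NC(=O)c1ccc(Sc2nc3cc(N)cc(N)c3nc2-c2ccccc2)cc1` gives < 100000 nM in this assay, again only a limit. For the measured compounds named here, the whole picture is therefore (the limit of < 100000 nM in this assay, at which 3 of the 3 values shown sit), and no step between any two measured compounds can be stated, since their values show only that none was resolved below the limit.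

Compound 4 `Nc1cc(N)c2nc(-c3ccccc3)c(Sc3ccc(Cl)c(Cl)c3)nc2c1` is the untested member. It differs from compound 3 as follows: 3,4-dichlorophenyl in place of 4-fluorophenyl on a sulfur. Going by the values given here, with every measured value stopping at the limit, this assay offers no step to guide a prediction. The change is expected to bring no step beyond the scatter, estimated as a number no lower from compound 3 to compound 4 (the limit leaves the size open). Compound 4 is expected to give about 100000 nM, within 20000 nM to 200000 nM, and most likely to be reported once more only as a limit.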

Compound 4, concentration lethal to 50% of the cells: < 100000 nM
Compound 4: only a limit was reported (the forecaster's own chance of this, stated with the estimate: 80%); the middle value lies on the limit itself.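

The step between compound 3 and compound 4 cannot be read, because both results in this assay are only limits: the limit of < 100000 nM in this assay, at which 4 of the 4 values shown sit.

The compounds shown leave open what actual value each of the four has, and so whether 3,4-dichlorophenyl in place of 4-fluorophenyl on a sulfur makes any difference in this assay.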